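This account rests on a few compounds, and the source may have more. Where it says the series, first, only, none or still open, it means among the compounds named here.

Compound 1 `S=c1oc(-c2ccc3c(c2)OCCO3)nn1CNc1ccccc1` gives 5140 nM in a functional assay, with a stated time of 6 min; on this read-out lower numbers stand for stronger inhibition and higher numbers for weaker inhibition. Among the measured compounds shown here, compound 2 `S=c1oc(-c2ccc3c(c2)OCCO3)nn1CNC1CCCCC1` gives 18400 nM in this assay, the higher of the two numbers measured so far, reached by a 3.6-fold higher number from compound 1 to compound 2 (0.55 log units; beyond the scatter). Compound 3 `S=c1oc(-c2ccc3c(c2)OCCO3)nn1CNc1cccc(Br)c1` carries 3-bromophenyl in place of cyclohexyl on an amine nitrogen. For the measured compounds named here, the one measured step that bears on this is a 3.6-fold higher number from compound 1 to compound 2 (0.55 log units; beyond the scatter), which compound 3 runs in the opposite direction by restoring an aromatic ring on the amine nitrogen; the bromine has no measured counterpart, so its share is unknown. A step of about a 3.7-fold lower number from compound 2 to compound 3 (0.57 log units; beyond the scatter) is therefore expected, toward a lower number. Compound 3 is estimated at 5000 nM, with a range from 2000 nM to 15000 nM.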

Compound 3, half-maximal inhibitory concentration: 10800 nM
The estimate for compound 3 lay 2.2-fold (0.33 log units) below the measured number; measured number inside the range.
By their numbers in this assay, from the lowest: compound 1; then compounds 3 and 2 (each within the scatter of the next).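

In this assay, 3-bromophenyl in place of cyclohexyl on an amine nitrogen gives a 1.7-fold lower number from compound 2 to compound 3 (0.23 log units; within the scatter), so this aromatic ring, once it carries bromo, is not distinguished from cyclohexyl. Bromo in place of hydrogen on an aromatic carbon gives a 2.1-fold higher number from compound 1 to compound 3 (0.32 log units; beyond the scatter), which shows that this part of the series responds to a substituent on the ring and not only to the ring type. Nothing available explains either step.

Still open, going by these compounds, is whether fluoro or methoxy in place of bromo would give the same result. On these data alone, whether a carboxylic acid on this ring would be tolerated also remains open.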